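Adding a Second Methoxy Group to a Pyridyl Chalcone

A few compounds are considered here, and "the series" means these few. Any claim that something is new, unique, unknown or untested is made for them only; others in the source may bear on it.

Of the compounds shown here, two have been measured in a functional assay on A549 cells (Homo sapiens) for antiproliferative activity, read by sulforhodamine B assay, with a stated time of 48 h; on this read-out lower numbers stand for stronger inhibition and higher numbers for weaker inhibition. Compound 1, `COc1ccc(/C=C/C(=O)c2ccccc2-c2ccc(F)cc2)cc1`, gives 140 nM. Compound 2, `COc1ccc(/C=C/C(=O)c2ccccc2-c2ccc(F)nc2)cc1`, gives 930 nM. Among the measured compounds shown here, the single measured step, a 6.6-fold higher number from compound 1 to compound 2 (0.82 log units; beyond the scatter), places compound 2 at the higher of the two numbers, so it is the weaker inhibitor of the pair.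

Compound 3, `COc1ccc(/C=C/C(=O)c2ccccc2-c2ccc(F)nc2)cc1OC`, differs from compound 2 by one change: methoxy in place of hydrogen on an aromatic carbon. The new group sits on an aromatic carbon of a six-membered aromatic ring of carbon only, ortho to a methoxy group and meta to a large group. For the measured compounds named here, the one measured step concerns a different part of the molecule, the exchange of 4-fluorophenyl for 6-fluoropyridin-3-yl, and so gives no direct guidance on what a second methoxy group does here. Going by the values given here, with no comparable step to lean on, the expectation for compound 3 in this assay is a change of a 1.2-fold lower number from compound 2 to compound 3 (0.07 log units; within the scatter), that is, none beyond the scatter. Compound 3 is therefore estimated at 800 nM, with a range from 250 nM to 2500 nM.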

Compound 3, half-maximal inhibitory concentration: 1200 nM
For compound 3 the middle estimate is 1.5-fold (0.18 log units) below the measured one; the range from low to high includes it.
By their numbers in this assay, from the lowest: compound 1; then compounds 2 and 3 (each within the scatter of the next).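

Methoxy in place of hydrogen on this carbon, ortho to the existing methoxy group and meta to a large group, comes out as a 1.3-fold higher number from compound 2 to compound 3 (0.11 log units; within the scatter) in this assay, so the two compounds cannot be told apart on this read-out. Among the compounds shown here, this is the first sign that this position of the ring can carry a methoxy group, with its two heavy atoms, without a measurable loss of antiproliferative activity, whereas the earlier exchange of 4-fluorophenyl for 6-fluoropyridin-3-yl, a 6.6-fold higher number from compound 1 to compound 2 (0.82 log units; beyond the scatter), moved the number beyond the scatter. No measurement is available that would explain this outcome.

For the compounds shown here, this change is seen in only one pair, so whether a second methoxy group would behave the same way on the core of compound 1, which carries the 4-fluorophenyl group, remains open. The compounds shown also do not tell what a different group on this same carbon, such as a hydroxyl, an amine or a longer ethoxy chain, would do in this assay.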